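Changing the aryl amine substituent of compound 2

This account rests on a few compounds, and the source may have more. Where it says the series, first, only, none or still open, it means among the compounds named here.

Compound 1 `Cc1cc(Nc2ccc(Br)cc2)nc(SCc2nc3ccccc3[nH]2)n1`: 42900 nM in a functional assay on ECa-109 cells (Homo sapiens) for cytotoxicity, read by MTT assay, with a stated time of 72 h; a higher number here means a weaker inhibitor, a lower number a stronger inhibitor
Compound 2 `COc1ccccc1Nc1cc(C)nc(SCc2nc3ccccc3[nH]2)n1`: 34400 nM in this assay

Compound 2 stands next to compound 1 at a distance of a 1.2-fold lower number from compound 1 to compound 2 (0.10 log units; within the scatter), a gap within the scatter, so the two are not distinguished. Compound 3 `Cc1cc(Nc2ccc(F)cc2)nc(SCc2nc3ccccc3[nH]2)n1` differs from compound 2 by 4-fluorophenyl in place of 2-methoxyphenyl on a nitrogen on an aromatic ring. Going by the values given here, the only measured step bears on this indirectly: replacing 4-bromophenyl by 2-methoxyphenyl gave a 1.2-fold lower number from compound 1 to compound 2 (0.10 log units; within the scatter), which moved this assay little, and compound 3 returns to a halogen-bearing phenyl resembling compound 1. The step of a 1.2-fold higher number from compound 2 to compound 3 (0.07 log units; within the scatter) is therefore expected to stay within the scatter. Compound 3 is estimated at 40000 nM, with a range of 15000 nM to 110000 nM.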

Compound 3, half-maximal inhibitory concentration: 69500 nM
The estimate for compound 3 lay 1.7-fold (0.24 log units) below the measured number; measured number inside the range.
By their numbers in this assay, from the lowest: compounds 2, 1 and 3 (each within the scatter of the next, the first and the last beyond it).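

In this assay, going by these compounds alone, this is the first change of the aryl group on this nitrogen that exceeds the scatter, though only modestly (a 2.0-fold higher number from compound 2 to compound 3 (0.31 log units; beyond the scatter)). The two halogens do not separate: fluoro in place of bromo on an aromatic carbon stays within the scatter (a 1.6-fold higher number from compound 1 to compound 3 (0.21 log units; within the scatter)). No available evidence accounts for the step from 2-methoxyphenyl to 4-fluorophenyl. That step exchanges both the group and where it sits on the phenyl ring, so the compounds shown cannot separate the two. As far as these compounds go, it remains open how 4-methoxyphenyl or 2-fluorophenyl would read, or a phenyl carrying a carboxylic acid.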